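This account rests on a few compounds, and the source may have more. Where it says the series, first, only, none or still open, it means among the compounds named here.

Three related compounds share one core and have been tested in a functional assay for antagonist activity at Alpha-1A adrenergic receptor (Oryctolagus cuniculus); on this read-out higher numbers stand for weaker binding and lower numbers for tighter binding. Compound 1 `CN(C)C(=O)c1cccnc1NCCCN1CCN(c2ccccc2OCC2CC2)CC1` gives 0.159 nM, compound 2 `Cc1ccccc1N1CCN(CCCNc2ncccc2C(=O)N(C)C)CC1` gives 2 nM, and compound 3 `CN(C)C(=O)c1cccnc1NCCCN1CCN(c2ccccc2Cc2ccccc2)CC1` gives 6.31 nM. Compound 2 stands second of these three: it lies a 13-fold higher number from compound 1 to compound 2 (1.10 log units; beyond the scatter) and it sits below compound 3, the step being a 3.2-fold higher number from compound 2 to compound 3 (0.50 log units; beyond the scatter).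

Compound 4 `COc1cc(O)ccc1N1CCN(CCCNc2ncccc2C(=O)N(C)C)CC1` has not yet been measured. It differs from compound 2 in one place: 4-hydroxy-2-methoxyphenyl in place of 2-methylphenyl on an amine nitrogen in a ring. For the measured compounds named here, no measured step swaps in a ring carrying two oxygen-bearing groups, so the closest guide is the same position in compound 1, where a cyclopropylmethoxy group on the ring gives the tightest binding of the set, the step being a 13-fold higher number from compound 1 to compound 2 (1.10 log units; beyond the scatter), while a benzyl group gives the loosest, the step being a 40-fold higher number from compound 1 to compound 3 (1.60 log units; beyond the scatter). A methoxy group and a hydroxyl group are expected to behave more like the oxygen-bearing group of compound 1 than like the carbon groups of compound 2 and compound 3, so the step of a 2.5-fold lower number from compound 2 to compound 4 (0.40 log units; beyond the scatter) is expected to run toward tighter binding. Compound 4 is therefore estimated at 0.8 nM, with a range from 0.15 nM to 4 nM.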

Compound 4, dissociation constant: 12.6 nM
Compound 4: the middle estimate sits 16-fold (1.20 log units) below what was measured, and the stated range ends below it.
By their numbers in this assay, from the lowest: compound 1; then compound 2; then compounds 3 and 4 (each within the scatter of the next).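

In this assay, replacing 2-methylphenyl with 4-hydroxy-2-methoxyphenyl on the ring nitrogen gives a 6.3-fold higher number from compound 2 to compound 4 (0.80 log units; beyond the scatter), so this change weakens binding in this pair. Oxygen-bearing groups on this aromatic ring therefore do not guarantee tight binding: compound 1 gives 0.159 nM with cyclopropylmethoxy, whereas compound 4 gives 12.6 nM with a hydroxyl and a methoxy group. No supporting measurement is available to explain the loss of binding in compound 4.

The two oxygen-bearing groups enter together, so the compounds shown cannot separate the contribution of the hydroxyl from that of the methoxy group. A plain 2-methoxyphenyl group and a 4-hydroxyphenyl group would separate them, while an amine or a fluorine in place of the hydroxyl would test what that part of the new group contributes.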